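Swapping the bicyclic ring on a urea nitrogen

The source may report more compounds than this note shows. Statements on the series, on what has been measured and on what is new or still open speak of the compounds shown alone.

Measured so far:
Compound 1, `O=C(Nc1cncc2ccccc12)N1CCN(Cc2cccc(Oc3ccc(Cl)cc3)c2)CC1`: 8.3 nM
Compound 2, `O=C(Nc1noc2ccncc12)N1CCN(Cc2cccc(Oc3ccc(Cl)cc3)c2)CC1`: 2200 nM

Both compounds were tested in an assay on isolated protein for inhibition of Fatty-acid amide hydrolase 1 (Rattus norvegicus), with a stated time of 60 min; on this read-out lower numbers stand for stronger inhibition and higher numbers for weaker inhibition. Compound 1 gives 8.3 nM and stands at the lowest number of the two, so it is the stronger inhibitor here. Compound 2 gives 2200 nM; the step of a 270-fold higher number from compound 1 to compound 2 (2.42 log units; beyond the scatter) shows how much is lost when the isoquinolin-4-yl group on the amide-type nitrogen is replaced by a five-membered/six-membered fused ring with more hetero atoms.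

Compound 3, `O=C(Nc1ccn2ccnc2c1)N1CCN(Cc2cccc(Oc3ccc(Cl)cc3)c2)CC1`, has not yet been measured. Compared with compound 1 the change is a group of 9 heavy atoms (7 carbon, 2 nitrogen; one five-membered aromatic ring with 2 hetero atoms, one six-membered aromatic ring with 1 hetero atom) in place of a group of 10 heavy atoms (9 carbon, 1 nitrogen; one six-membered aromatic ring of carbon only, one six-membered aromatic ring with 1 hetero atom), on an amide-type nitrogen. Among the compounds with values here, this resembles the only step on record, from compound 1 to compound 2, in that a ring system of the same size class and containing two nitrogens again takes the place of the isoquinolin-4-yl group, though the new ring is not the same as in compound 2. On that basis the step expected is an 18-fold higher number from compound 1 to compound 3 (1.26 log units; beyond the scatter), which would mean a move toward weaker inhibition, though a smaller one than the step to compound 2 and still beyond the scatter. For compound 3 the expected value is 150 nM, within a range of 20 nM to 1500 nM.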

Compound 3, half-maximal inhibitory concentration: 2600 nM
The estimate for compound 3 lay 17-fold (1.24 log units) below the measured number, and the stated range ends below it.
By their numbers in this assay, from the lowest: compound 1; then compounds 2 and 3 (each within the scatter of the next).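

In this assay, a second replacement for isoquinolin-4-yl on the amide-type nitrogen gives a 310-fold higher number from compound 1 to compound 3 (2.50 log units; beyond the scatter) and so shows that the large loss seen with compound 2 is not confined to that one replacement group. The two entering groups are not identical, since the group in compound 2 contains an oxygen while the group in compound 3 contains only carbon and nitrogen, yet a 1.2-fold higher number from compound 2 to compound 3 (0.07 log units; within the scatter) leaves the two numbers indistinguishable in this assay. Nothing on hand explains why either group gives so much weaker inhibition than isoquinolin-4-yl.

Both entering groups replace the all-carbon six-membered ring of isoquinolin-4-yl with a five-membered aromatic ring containing hetero atoms, so these compounds cannot show whether the loss follows from removing that all-carbon ring or from adding the five-membered ring and its hetero atoms. A naphthalen-1-yl group, which has two six-membered rings and no ring nitrogen, and a pyridin-3-yl group, which has a single six-membered ring with one nitrogen, would each test a different part of that question on the same shared core.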